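The source may report more compounds than this note shows. Statements on the series, on what has been measured and on what is new or still open speak of the compounds shown alone.

Compound 1, `NC(=O)c1c(NC(=O)c2ccc(C(F)(F)F)cc2)sc2c1CCN(Cc1ccc(Cl)cc1Cl)C2`, gives 14900 nM in a functional assay on HL-60 cells (Homo sapiens) for antiproliferative activity, with a stated time of 24 h; on this read-out higher numbers stand for weaker inhibition and lower numbers for stronger inhibition. Compound 2, `Cc1ccc(C(=O)Nc2sc3c(c2C(N)=O)CCN(Cc2c(Cl)cccc2Cl)C3)cc1`, gives 10000 nM in this assay. Compound 3, `NC(=O)c1c(NC(=O)c2ccccc2Cl)sc2c1CCN(C(=O)Nc1ccccc1Cl)C2`, gives 12500 nM in this assay.

Compound 3 holds the second highest of the three numbers. Its nearest neighbour is compound 1, whose number is slightly higher, and compound 2 has a slightly lower number; both gaps lie within the scatter, so the three compounds cannot be told apart on this read-out. Among the measured compounds shown here, no pair of measured compounds differs in only one place, so no measured step is available to guide the next move.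

Compound 4, `NC(=O)c1c(NC(=O)c2ccccc2Cl)sc2c1CCN(C(=S)Nc1cccnc1)C2`, differs from compound 3 at one place: a group of 9 heavy atoms (6 carbon, 2 nitrogen, 1 sulfur; one six-membered aromatic ring with 1 hetero atom) in place of a group of 10 heavy atoms (7 carbon, 1 nitrogen, 1 oxygen, 1 chlorine; one six-membered aromatic ring of carbon only), on an amine nitrogen in a ring. For the measured compounds named here, with no measured step for comparison and all three measured compounds standing close together at weak inhibition, only a small step is expected in this assay, with no clear direction beyond the scatter. Compound 4 is therefore estimated at 12000 nM, within 4000 nM to 40000 nM, a step of a 1.0-fold lower number from compound 3 to compound 4 (0.02 log units; within the scatter) from compound 3.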

Compound 4, half-maximal inhibitory concentration: 33900 nM
Beside the measured number, compound 4's estimate is 2.8-fold (0.45 log units) below it; the measured number falls inside the stated range.
By their numbers in this assay, from the lowest: compounds 2, 3 and 1 (each within the scatter of the next); then compound 4.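

In this assay the entry of the new group in place of (2-chlorophenyl)carbamoyl, on an amine nitrogen in a ring, gives a 2.7-fold higher number from compound 3 to compound 4 (0.43 log units; beyond the scatter) and so weaker inhibition. Among the compounds shown here, this is the first step in the set to pass the scatter, which shows that the read-out does respond to what this nitrogen carries. The swap changes several things at once, since sulfur enters, oxygen and chlorine leave, and the aromatic ring gains a hetero atom, so the step cannot be assigned to any one of these parts. Nothing at hand bears on why the number rose.

On these data alone, it remains open whether sulfur or the ring hetero atom accounts for the step. As far as these compounds go, it is also open how a plain acetyl group on this nitrogen would stand.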